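Longer ester chains on the succinamide linker

The source may hold more compounds than are shown below. What is called first, only, known or untested is meant among the compounds shown, and "the series" means these compounds.

Three measured compounds share one core and differ only in the ester chain. In a functional assay on A549 cells (Homo sapiens) for cytotoxicity, read by MTT assay, with a stated time of 24 h, tested at 10 uM (on this read-out higher numbers stand for a weaker effect at the one concentration tested and lower numbers for a stronger effect), compound 1 `CCCOC(=O)CCC(=O)N1CCN(CCCOc2cc3c(Nc4ccc(F)c(Cl)c4)ncnc3cc2OC)CC1` gives 95.1%, compound 2 `CCCCCCCCCCCCCOC(=O)CCC(=O)N1CCN(CCCOc2cc3c(Nc4ccc(F)c(Cl)c4)ncnc3cc2OC)CC1` gives 93.7% and compound 3 `CCCCCCCCCCCCCCOC(=O)CCC(=O)N1CCN(CCCOc2cc3c(Nc4ccc(F)c(Cl)c4)ncnc3cc2OC)CC1` gives 100%, the highest of the three numbers, yet every step among them is within the scatter: a number 1.4 percentage points lower from compound 1 to compound 2 (within the scatter), a number 4.9 percentage points higher from compound 1 to compound 3 (within the scatter), a number 6.3 percentage points higher from compound 2 to compound 3 (within the scatter).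

Compound 4 `CCCCCCCCCCCCCCCOC(=O)CCC(=O)N1CCN(CCCOc2cc3c(Nc4ccc(F)c(Cl)c4)ncnc3cc2OC)CC1` extends compound 3 by one more carbon: methyl in place of hydrogen on a saturated chain carbon, ten or more bonds along the chain from an oxygen next to a carbonyl group. The step of a number 6.3 percentage points higher from compound 2 to compound 3 (within the scatter) is the same kind of change and produced nothing beyond the scatter, and the wider comparison a number 4.9 percentage points higher from compound 1 to compound 3 (within the scatter) is likewise flat. For compound 4 the expected step is therefore a number 3 percentage points lower from compound 3 to compound 4 (within the scatter), none beyond the scatter. Compound 4 is estimated at 97%, between 87% and 105%.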

Compound 4, a percentage reported as activity, at one concentration (the size of the read-out at that concentration, not a potency): 92%
Compound 4: the middle estimate sits 5 percentage points above what was measured, and the stated range covers the measured number.
By their numbers in this assay, from the lowest: compounds 4, 2, 1 and 3 (each within the scatter of the next).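

In this assay the extra carbon again leaves the read-out flat, with a number 8 percentage points lower from compound 3 to compound 4 (within the scatter) and a number 1.7 percentage points lower from compound 2 to compound 4 (within the scatter) and a number 3.1 percentage points lower from compound 1 to compound 4 (within the scatter). Even dodecyl in place of hydrogen, the largest change at this place among the compounds shown, stays inside the scatter, so chain length here has no visible effect up to compound 4. No measurement shown explains this flat result. Open, going by these compounds, is whether an amine or a carboxylic acid at the end of the ester chain, or a still longer chain, would give a number beyond the scatter.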